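Swapping a Furan Ketone for a Propyl Amide

The source may report more compounds than this note shows. Statements on the series, on what has been measured and on what is new or still open speak of the compounds shown alone.

Compound 1, `C[C@H]1C[C@@H]1C(=O)N1CC2CNCC2C1`: 13000 nM
Compound 2, `O=C(c1ccco1)[C@H]1C[C@@H]2CNC[C@@H](C2)C1`: "not determined" (no result reported)

In an assay on CHO cells for displacement of a labelled ligand from Neuronal acetylcholine receptor; alpha3/beta4 (Homo sapiens), read by scintillation counting, with a stated time of 2 h (a lower number here means a stronger inhibitor, a higher number a weaker inhibitor), compound 1 gives 13000 nM, a weak result. In this assay compound 2 is recorded as "not determined" (no result reported), so no number places it. Compound 3, `CCCNC(=O)[C@H]1C[C@@H]2CNC[C@@H](C2)C1`, differs from compound 2 by propylamino in place of furan-2-yl on a carbonyl carbon. No measured step tells the size or direction of this change, and compound 2 gives no anchor, so the expectation must rest on the only number shown, that of compound 1, which is weak; compound 3 is expected to land in a similarly weak region. Compound 3 is expected to give about 12000 nM in this assay, within a range from 2000 nM to 60000 nM.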

Compound 3, inhibition constant: 4000 nM
Compound 3: middle estimate off by 3.0-fold (0.48 log units), on the high side, and the stated range covers the measured number.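

Among these compounds, compound 2 has no number to compare, so no step from it to compound 3 can be read. The compounds shown leave open how furan-2-yl and propylamino compare on this carbonyl carbon. No supporting evidence bears on this result.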